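Isopropyl for methyl on the ring nitrogen

The source may hold more compounds than are shown below. What is called first, only, known or untested is meant among the compounds shown, and "the series" means these compounds.

Of the compounds shown here, two have been measured in an assay on cells for inhibition of Amine oxidase [flavin-containing] B (Homo sapiens), read by fluorescence, with stated times of 30 min and 15 min, tested at 1 uM; a lower number here means less inhibition, a higher number more inhibition at the concentration tested (going by the name of the read-out). Compound 1 `Cn1c(=O)[nH]c2ccc(OCCOc3ccc(Cl)cc3)cc21` gives 9.94% in this assay, the lower of the two numbers. Compound 2 `Cn1c(=O)[nH]c2ccc(OCCc3cccc(Cl)c3)cc21` gives 13.7% in this assay, a number within the scatter of compound 1, so no order between the two can be stated. Both show only weak inhibition at the concentration tested. For the measured compounds named here, no pair of measured compounds differs in a single place, so no measured step is available as a guide.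

Compound 3 `CC(C)n1c(=O)[nH]c2ccc(OCCOc3ccc(Cl)cc3)cc21` is the next to be measured in this assay. It differs from compound 1 by isopropyl in place of methyl on an aromatic nitrogen. Because compound 1 sits at 9.94% and compound 2 at 13.7%, the starting point is low, yet nothing in the two measured numbers points to a step beyond the scatter in either direction. The expectation for compound 3 in this assay is therefore a step of about a number 2.1 percentage points higher from compound 1 to compound 3 (within the scatter), within the scatter. Compound 3 is estimated at 12%, with a range from 3% to 25%.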

Compound 3, a percentage reported as inhibition, at one concentration (the size of the read-out at that concentration, not a potency): 18.2%
Compound 3: the middle estimate sits 6.2 percentage points below what was measured; the measured number falls inside the stated range.
By their numbers in this assay, from the lowest: compounds 1, 2 and 3 (each within the scatter of the next).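

In this assay, for the compounds shown here, isopropyl in place of methyl on an aromatic nitrogen gives a number 8.3 percentage points higher from compound 1 to compound 3 (within the scatter) and so provides the first reading of a single change. The ring nitrogen therefore carries isopropyl as well as methyl without a step beyond the scatter, and this one change establishes neither a gain nor a loss of inhibition at the concentration tested. No measurement is available that would bear on the size of this step or explain it.

The compounds shown leave open whether a longer chain, such as n-butyl, or a benzyl group or a chain ending in an amine or a carboxylic acid on this nitrogen would produce a step beyond the scatter, since methyl and isopropyl alone give only a narrow view of the position. On these data alone, it also remains open whether isopropyl on the core of compound 2, with its different side chain, would give a step similar to the one seen here, so the reading cannot yet be extended beyond this single pair.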